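The source may report more compounds than this note shows. Statements on the series, on what has been measured and on what is new or still open speak of the compounds shown alone.

Among the three compounds measured in an ADME assay on microsomes from liver (Mus musculus) for metabolic stability, using NADPH, with a stated time of 10 min (on this read-out lower numbers stand for a less stable compound and higher numbers for a more stable compound), compound 2 `CCCCc1nc(=O)c(S(=O)(=O)c2ccc(-c3ccc(F)nc3)cc2)c(O)n1-c1c(OC)cccc1OC` stands highest, giving 69%. Compound 1 `CCCCc1nc(=O)c(S(=O)(=O)c2ccc(-c3cccnc3)cc2)c(O)n1-c1c(OC)cccc1OC` gives 57%, and the step of a number 12 percentage points higher from compound 1 to compound 2 (beyond the scatter), which is a fluoro in place of hydrogen on an aromatic carbon. Compound 3 `COc1cccc(OC)c1-n1c(CCC(C)C)nc(=O)c(S(=O)(=O)c2ccc(-c3ccc(F)nc3)cc2)c1O` gives 31%, and the step of a number 38 percentage points lower from compound 2 to compound 3 (beyond the scatter), which is a methyl in place of hydrogen on a saturated chain carbon bound to two saturated chain carbons.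

Compound 4 `CCCCc1nc(=O)c(S(=O)(=O)c2ccccc2)c(O)n1-c1c(OC)cccc1OC` differs from compound 2 by hydrogen in place of 6-fluoropyridin-3-yl on an aromatic carbon. The step from compound 1 to compound 2 bears on this change most directly, since it also alters the 6-fluoropyridin-3-yl ring, and it was modest; the step from compound 2 to compound 3 touches the chain, not this ring, and offers no direct guide. For the measured compounds named here, no measured step removes the whole ring, so the expectation rests on the modest loss seen when only the fluoro is taken away from compound 2 to compound 1.

Compound 4 is therefore expected to fall somewhat below compound 2, with an estimated step of a number 19 percentage points lower from compound 2 to compound 4 (beyond the scatter), and an estimated value of 50%, ranging from 30% to 70%.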

Compound 4, percent of the compound remaining: 79%
Estimate against measurement, compound 4: 29 percentage points below, outside the stated range (above it).
By their numbers in this assay, from the lowest: compound 3; then compound 1; then compounds 2 and 4 (each within the scatter of the next).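

The new result shows that this aromatic carbon, para to a large group, does not need the ring at all to give a high number in this assay: a number 10 percentage points higher from compound 2 to compound 4 (within the scatter), so removing the whole 6-fluoropyridin-3-yl leaves no change that can be told from the usual scatter. The earlier compounds shown here showed only that adding a fluoro to the pyridine ring raised the number, which could suggest that the ring was a useful part of the molecule, yet the comparison with the unfluorinated ring gives a number 22 percentage points higher from compound 1 to compound 4 (beyond the scatter), a gain beyond the scatter when pyridin-3-yl is replaced by hydrogen. Read together, these steps suggest that the fluoro in compound 2 brings the number to a level that the compound without any ring reaches as well, and nothing in the data shown explains these numbers.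

The compounds shown leave open how a plain phenyl ring or an amine would read at this same carbon. They also leave open whether the extra methyl on the chain would lower the number as sharply in a compound that carries hydrogen at this carbon.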